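This account rests on a few compounds, and the source may have more. Where it says the series, first, only, none or still open, it means among the compounds named here.

In an assay on cells for agonist activity at probable G-protein coupled receptor 34 (Mus musculus), with a stated time of 1 h (a lower number here means a smaller maximal response, a higher number a larger maximal response), compound 1 `N[C@@H](COP(=O)(O)OCCCOC(=O)CCc1ccccc1OCc1cccc(Oc2cccc(Cl)c2)c1)C(=O)O` gives 17.1%. Among the compounds with values here, compound 2 `N[C@@H](COP(=O)(O)OCCCOC(=O)CCc1ccccc1OCc1cccc(Oc2ccc(Cl)c(Cl)c2)c1)C(=O)O` gives 18% in this assay, the only other number here, and it sits within the scatter of compound 1. Within the data shown here, the single measured step, a number 0.9 percentage points higher from compound 1 to compound 2 (within the scatter), is the one that bears on halogen changes at this position and was small. Compound 3 `N[C@@H](COP(=O)(O)OCCCOC(=O)CCc1ccccc1OCc1cccc(Oc2ccc(F)cc2)c1)C(=O)O` differs from compound 2 by 4-fluorophenyl in place of 3,4-dichlorophenyl on an oxygen on an aromatic ring. Since only halogens on the group attached to that oxygen change, no step beyond the scatter is expected; the estimated step is a number 1 percentage points lower from compound 2 to compound 3 (within the scatter). Compound 3 is therefore expected to give 17%, between 9% and 27%, in this assay.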

Compound 3, largest response reached (Emax), in percent of the reference or control that the assay uses: 18.7%
Estimate against measurement, compound 3: 1.7 percentage points below; the measured number falls inside the stated range.
By their numbers in this assay, from the lowest: compounds 1, 2 and 3 (each within the scatter of the next).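

Swapping chlorine for fluorine on this ring leaves the maximal response in this assay essentially unchanged, with a number 0.7 percentage points higher from compound 2 to compound 3 (within the scatter) and a number 1.6 percentage points higher from compound 1 to compound 3 (within the scatter). So 4-fluorophenyl on this oxygen cannot be told apart from either 3,4-dichlorophenyl or 3-chlorophenyl, and the flat picture now covers fluorine as well as chlorine. Nothing available explains why these halogen changes leave the response flat. Going by these compounds, all three compounds carry only halogens on this ring, so it remains open whether an amine or a carboxylic acid there would leave the response in the same range. On these data alone, whether a longer chain elsewhere on the shared core would move it is also open.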